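A few compounds are considered here, and "the series" means these few. Any claim that something is new, unique, unknown or untested is made for them only; others in the source may bear on it.

In an assay on CHO-K1 cells for antagonist activity at transient receptor potential cation channel subfamily V member 1 (Homo sapiens), read by FLIPR (on this read-out higher numbers stand for weaker inhibition and lower numbers for stronger inhibition), three compounds of one series have numbers. Compound 1 `CC(C)CCSc1nc(C(F)(F)F)ccc1CNC(=O)C(C)c1ccc(NS(C)(=O)=O)c(F)c1` gives 82 nM. Compound 2 `CC1CCN(CCCSc2nc(C(F)(F)F)ccc2CNC(=O)C(C)c2ccc(NS(C)(=O)=O)c(F)c2)CC1` gives 217 nM in this assay, and compound 3 `CC(C(=O)NCc1ccc(C(F)(F)F)nc1SCc1ccc(Cl)cc1)c1ccc(NS(C)(=O)=O)c(F)c1` gives 674 nM in this assay. Compound 2 thus holds the second highest of the three numbers: the nearest is compound 1, with a 2.6-fold higher number from compound 1 to compound 2 (0.42 log units; beyond the scatter), and the furthest is compound 3, with a 3.1-fold higher number from compound 2 to compound 3 (0.49 log units; beyond the scatter).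

Compound 4 `Cc1ccc(CSc2nc(C(F)(F)F)ccc2CNC(=O)C(C)c2ccc(NS(C)(=O)=O)c(F)c2)cc1` differs from compound 2 by 4-methylphenyl in place of 2-(4-methylpiperidin-1-yl)ethyl on a saturated chain carbon bound to a sulfur. Among the measured compounds shown here, two measured steps bear on this change. The step of a 3.1-fold higher number from compound 2 to compound 3 (0.49 log units; beyond the scatter) removes the same chain from the same carbon in favour of a substituted phenyl and raises the number. The step of an 8.2-fold higher number from compound 1 to compound 3 (0.91 log units; beyond the scatter) points the same way, from a shorter branched chain to that phenyl. For the measured compounds named here, the change to compound 4 is of the same kind, with 4-methylphenyl rather than 4-chlorophenyl entering, and no measured pair separates these two phenyls. Compound 4 is therefore expected to show a 2.5-fold higher number from compound 2 to compound 4 (0.40 log units; beyond the scatter), an upward step in this assay beyond the scatter and near the size seen between compound 2 and compound 3. Compound 4 is estimated at 550 nM in this assay, within a range from 200 nM to 1500 nM.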

Compound 4, half-maximal inhibitory concentration: 764 nM
For compound 4 the middle estimate is 1.4-fold (0.14 log units) below the measured one; the measured number falls inside the stated range.
By their numbers in this assay, from the lowest: compound 1; then compound 2; then compounds 3 and 4 (each within the scatter of the next).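

In this assay, methyl in place of chloro on an aromatic carbon gives a 1.1-fold higher number from compound 3 to compound 4 (0.05 log units; within the scatter), so this change leaves the number within the scatter and the 4-methylphenyl and 4-chlorophenyl groups cannot be told apart here. The steps of a 3.5-fold higher number from compound 2 to compound 4 (0.55 log units; beyond the scatter) and a 9.3-fold higher number from compound 1 to compound 4 (0.97 log units; beyond the scatter) both rise beyond the scatter, which shows that the upward shift on the saturated chain carbon bound to a sulfur is not confined to the 4-chlorophenyl group but appears with both phenyl groups shown, against either the 2-(4-methylpiperidin-1-yl)ethyl or the isobutyl group. No supporting measurement is available that could account for these steps.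

The compounds shown leave open whether a longer chain between the sulfur and the phenyl ring would bring the number back towards that of compound 1, and whether a nitrile, a methoxy group or a carboxylic acid in place of the methyl would separate itself from the methyl and chloro groups. They also leave open whether an open-chain amine such as dimethylamino, in place of the 4-methylpiperidin-1-yl group of compound 2, would give a similar number.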